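Cytotoxicity notes: compound 1 to compound 3

This account rests on a few compounds, and the source may have more. Where it says the series, first, only, none or still open, it means among the compounds named here.

Compound 1 `Cc1cc(C)cc(S(=O)(=O)c2c(C(=O)NCc3cccc(F)c3F)[nH]c3ccc(Cl)cc23)c1` is known only as a limit in an ADME assay on MT4 cells (Homo sapiens) for cytotoxicity, read by MTT assay; on this read-out lower numbers stand for higher toxicity in this test and higher numbers for lower toxicity in this test. In this assay compound 1 gives > 51100 nM, a limit of the assay rather than a number. Compound 2 `Cc1cc(C)cc(S(=O)(=O)c2c(C(=O)NCC(=O)NCc3ccco3)[nH]c3ccc(Cl)cc23)c1` likewise stops at a limit; in this assay compound 2 gives > 50000 nM. The step that the two limits leave unreadable from compound 1 to compound 2 cannot be sized, as the two values sit at the limit of > 51100 nM in this assay, at which 1 of the 2 values shown sits, and (the limit of > 50000 nM in this assay, at which 1 of the 2 values shown sits).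

Compound 3 `Cc1cc(C)cc(S(=O)(=O)c2c(C(=O)NC(C)C(=O)NCc3ccncc3)[nH]c3ccc(Cl)cc23)c1` differs from compound 1 by a group of 12 heavy atoms (9 carbon, 2 nitrogen, 1 oxygen; one six-membered aromatic ring with 1 hetero atom) in place of a group of 9 heavy atoms (7 carbon, 2 fluorine; one six-membered aromatic ring of carbon only), on an amide-type nitrogen. Going by the values given here, the only measured step, a step that the two limits leave unreadable from compound 1 to compound 2, also removes the 2,3-difluorobenzyl group and is unreadable in size. No step beyond the scatter is therefore expected in this assay, and compound 3 is expected to stay at the limit of the assay. The step expected here is a step that the limit leaves unreadable from compound 1 to compound 3. For compound 3 the estimate in this assay is 60000 nM, within 30000 nM to 150000 nM.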

Compound 3, half-maximal cytotoxic concentration: 19500 nM
Compound 3: middle estimate off by 3.1-fold (0.49 log units), on the high side; the measured number lies below the stated range.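

In this assay, going by these compounds alone, the amide-type nitrogen now gives the first readable steps: an at least 2.6-fold lower number from compound 1 to compound 3 (0.41 log units; beyond the scatter) and an at least 2.5-fold lower number from compound 2 to compound 3 (0.40 log units; beyond the scatter), so a change at this place can lower the number beyond the scatter. The first of these steps gives only a minimum size because compound 1 stops at a limit of the assay: the limit of > 51100 nM in this assay, at which 1 of the 3 values shown sits. The second gives only a minimum size because compound 2 also stops at a limit of the assay: the limit of > 50000 nM in this assay, at which 1 of the 3 values shown sits.

The entering group changes as a whole, so the compounds shown do not tell which part of it goes with the lower number. Going by these compounds, how a carboxylic acid or a longer chain on this nitrogen would read in this assay also stays open.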